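This account rests on a few compounds, and the source may have more. Where it says the series, first, only, none or still open, it means among the compounds named here.

The measured compounds are: compound 1 `O=c1c(Cl)c(CSC(=S)N2CCOCC2)oc2ccccc12` with 4500 nM; compound 2 `O=c1cc(CSC(=S)N2CCCCC2)oc2cc(Cl)ccc12`; compound 3 `CCOC(=O)c1cc(=O)c2cc(CSC(=S)N(C)c3ccccc3)ccc2o1` with 18100 nM.

These numbers come from a functional assay on HeLa cells (Homo sapiens) for antiproliferative activity, read by MTT assay, with a stated time of 72 h; a higher number here means a weaker inhibitor, a lower number a stronger inhibitor. Compound 2 gives only a limit of the assay, > 25000 nM, and not a number (the limit of > 25000 nM in this assay, at which 1 of the 3 values shown sits). Among the two numbers that exist, compound 3 stands highest, and the nearest number, that of compound 1, is lower by more than the usual scatter, so compound 1 counts as the stronger inhibitor of the pair. Going by the values given here, compound 1 and compound 3 also differ in their cores, so no single step between measured compounds can be separated out.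

The step that follows goes from compound 3 to compound 4 `CCOC(=O)c1cc(=O)c2cc(CSC(=S)N(C(C)C)C(C)C)ccc2o1`, which has not yet been measured in this assay. The change is diisopropylamino in place of methyl(phenyl)amino on a thiocarbonyl carbon. No comparable step between measured compounds is available, so nothing shown tells which way this exchange moves the number. The writer therefore expects a step no larger than the scatter, a 1.1-fold higher number from compound 3 to compound 4 (0.04 log units; within the scatter). For compound 4 in this assay he estimates 20000 nM, with a range from 8000 nM to 50000 nM, and notes that a result reported only as a limit would not be surprising.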

Compound 4, half-maximal inhibitory concentration: > 25000 nM
Compound 4: no number, only a limit (the forecaster's own chance of this, stated with the estimate: 35%); at least 1.2-fold (0.09 log units) between middle value and limit.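

In this assay compound 4 gives > 25000 nM, which is a limit of the assay and not a number. Going by these compounds alone, for the first time, a single place can be followed on one shared core: replacing methyl(phenyl)amino, with its six-membered aromatic ring of carbon only, by diisopropylamino, with no ring, on a thiocarbonyl carbon gives an at least 1.3-fold higher number from compound 3 to compound 4 (0.14 log units; that floor lies within the scatter), so this exchange brings no stronger inhibition into view, though the floor of the step does not establish a change beyond the scatter. The true size of the step remains hidden, and the reading is bounded by the assay's upper limit: the limit of > 25000 nM in this assay, at which 2 of the 4 values shown sit.

The steps that would link compound 1 or compound 2 to this pair cannot be read, since those compounds differ in more than one place. Still open, as far as these compounds go, is whether a small dialkylamine such as dimethylamino, a cyclic amine such as pyrrolidine, or a methoxy group on the phenyl ring of methyl(phenyl)amino would give a measurable number on this core, and so whether the aromatic ring itself matters at this position.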